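Thiourea-linked anilinoquinazolines: varying the aryl amine substituent

This account rests on a few compounds, and the source may have more. Where it says the series, first, only, none or still open, it means among the compounds named here.

The measured compounds and their values in a functional assay on A-431 cells (Homo sapiens) for antiproliferative activity, read by MTT assay, with a stated time of 72 h; on this read-out lower numbers stand for stronger inhibition and higher numbers for weaker inhibition:

Compound 1 `NS(=O)(=O)c1ccc(NC(=S)Nc2ccc3ncnc(Nc4ccc(F)c(Cl)c4)c3c2)cc1` gives 37600 nM.
Compound 2 `C#Cc1cccc(Nc2ncnc3ccc(NC(=S)Nc4ccc(S(N)(=O)=O)cc4)cc23)c1` gives 15300 nM.
Compound 3 `NS(=O)(=O)c1ccc(NC(=S)Nc2ccc3ncnc(Nc4ccc(C(F)(F)F)cc4)c3c2)cc1` gives 18000 nM.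

Compound 3 holds the second highest number of the three. Its nearest neighbour is compound 2, a pairing that the data place within the scatter, so the two cannot be ordered; its furthest is compound 1, which stands beyond the scatter (a 2.1-fold lower number from compound 1 to compound 3 (0.32 log units; beyond the scatter)).

Compound 4 `NS(=O)(=O)c1ccc(NC(=S)Nc2ccc3ncnc(Nc4cccc(Cl)c4)c3c2)cc1` is not yet measured. It differs from compound 3 in one place: 3-chlorophenyl in place of 4-(trifluoromethyl)phenyl on a nitrogen on an aromatic ring. Going by the values given here, no measured step involves 3-chlorophenyl itself. Among the compounds with values here, the steps that bear on this position are a 2.1-fold lower number from compound 1 to compound 3 (0.32 log units; beyond the scatter), a 2.5-fold lower number from compound 1 to compound 2 (0.39 log units; beyond the scatter) and a 1.2-fold higher number from compound 2 to compound 3 (0.07 log units; within the scatter), which together show that exchanging the aryl group on this nitrogen moves the number only modestly, with compound 1 carrying a chlorine on its aryl group giving the highest number of the set.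

On that basis the step of a 1.4-fold higher number from compound 3 to compound 4 (0.14 log units; within the scatter) is expected to be small, if anything toward a higher number. Compound 4 is therefore estimated at 25000 nM, within a range of 10000 nM to 65000 nM.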

Compound 4, half-maximal inhibitory concentration: 15000 nM
The estimate for compound 4 lay 1.7-fold (0.22 log units) above the measured number, and the stated range covers the measured number.
By their numbers in this assay, from the lowest: compounds 4, 2 and 3 (each within the scatter of the next); then compound 1.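

Compound 4 shows that a chlorine on this aryl group does not by itself go with the high number of compound 1. In this assay, the 3-chlorophenyl group cannot be told apart from 4-(trifluoromethyl)phenyl (a 1.2-fold lower number from compound 3 to compound 4 (0.08 log units; within the scatter)), nor is chloro in place of ethynyl on an aromatic carbon distinguishable (a 1.0-fold lower number from compound 2 to compound 4 (0.01 log units; within the scatter)), so three different aryl groups now form one group within the scatter. Going by these compounds alone, the only step beyond the scatter that keeps the chlorine is hydrogen in place of fluoro on an aromatic carbon (a 2.5-fold lower number from compound 1 to compound 4 (0.40 log units; beyond the scatter)), which places the separation of compound 1 from the others on that single exchange, although the step remains modest.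

The compounds shown leave open whether an unsubstituted phenyl, or a methoxy group or an amine on this aryl ring, would move the number further than these groups do, and whether a fluoro alone would raise it as it does alongside the chlorine in compound 1. Nothing available here accounts for why the fluoro exchange registers while the other aryl exchanges do not.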